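Swapping Fluoro for Chloro on a Weak Inhibitor

A few compounds are considered here, and "the series" means these few. Any claim that something is new, unique, unknown or untested is made for them only; others in the source may bear on it.

Among the measured compounds shown here, compound 3 `O=C1/C(=C/c2ccc(F)cc2)CCCc2ccccc21` is the only compound here with a true number: in a functional assay on MOLT-4 cells (Homo sapiens) for inhibition (a lower number here means a stronger inhibitor, a higher number a weaker inhibitor), compound 3 gives 53600 nM. Compound 1 `O=C1/C(=C/c2ccc(Cl)cc2)Cc2ccccc21` reads > 500000 nM, which is a limit of the assay and not a number. Compound 2 `Cc1ccc(/C=C2\Cc3ccccc3C2=O)cc1` reads > 500000 nM, which is also only a limit. This leaves the data with the limit of > 500000 nM in this assay, at which 2 of the 3 values shown sit, so compound 3 has no exact value to be compared against.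

The next candidate, compound 4 `O=C1/C(=C/c2ccc(Cl)cc2)CCCc2ccccc21`, differs from compound 3 in a single exchange: chloro in place of fluoro on an aromatic carbon. The fluoro group is replaced by a chloro group on the same aromatic carbon, and the rest of the structure stays the same.

For the measured compounds named here, only one measured step can be consulted, and it is a step that the two limits leave unreadable from compound 1 to compound 2. It also replaces a group on an aromatic carbon, but it has no readable size to carry over. Going by the values given here, no measured step shows what this exchange does in this assay, so no direction can be favoured, and a change beyond the usual scatter is not expected. The estimate therefore stays anchored on compound 3 at 53600 nM. The expected change is a 1.1-fold lower number from compound 3 to compound 4 (0.03 log units; within the scatter). For compound 4 the estimated value is 50000 nM, with an expected range from 18000 nM to 150000 nM.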

Compound 4, half-maximal inhibitory concentration: 33000 nM
The estimate for compound 4 lay 1.5-fold (0.18 log units) above the measured number; low and high end bracket the measured number.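

In this assay, the exchange of fluoro for chloro on an aromatic carbon, para to a large group, gives a 1.6-fold lower number from compound 3 to compound 4 (0.21 log units; within the scatter), so this pair does not separate the two groups at this position. Among the compounds shown here, this is the first step with a readable size, and it shows that this exchange, taken alone, does not move the number beyond what repeated measurements would be expected to scatter. The only earlier step, from compound 1 to compound 2, cannot be read, and those two compounds remain fixed at a limit rather than a number: the limit of > 500000 nM in this assay, at which 2 of the 4 values shown sit.

On these data alone, it remains open whether a group of a different kind at this same position, such as an amine or a carboxylic acid, would shift the number beyond the scatter, since fluoro and chloro are each a single atom and neither carries a hydrogen-bond donor, a hydrogen-bond acceptor or a net charge. Both exact numbers also come from one shared core, so the compounds shown give no measured size for any change made to the core itself.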